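Diethylamino to pyrazolyl at the chain end of compound 3

The compounds below may be only part of what the source reports. "The series", "measured", "known", "first", "only" and "open" are said of these compounds alone.

Three compounds share one core and differ only in what hangs from the saturated chain carbon bound to an aromatic carbon. Compound 1 `CCCCNc1nc(N)nc(C)c1C` carries hydrogen there; in an assay on HEK293 cells for agonist activity at Toll-like receptor 8 (Homo sapiens), read by spectrophotometry (on this read-out higher numbers stand for an effect only at larger amounts of compound and lower numbers for an effect already at smaller amounts), compound 1 gives 3280 nM. Compound 2 `CCCCNc1nc(N)nc(C)c1CCCCO` carries 3-hydroxypropyl, and in this assay compound 2 gives 1310 nM, a change described as a 2.5-fold lower number from compound 1 to compound 2 (0.40 log units; beyond the scatter). Compound 3 `CCCCNc1nc(N)nc(C)c1CCCN(CC)CC` carries 2-(diethylamino)ethyl, and in this assay compound 3 gives 254 nM, the lowest of the three numbers; the steps leading to it read a 13-fold lower number from compound 1 to compound 3 (1.11 log units; beyond the scatter) and a 5.2-fold lower number from compound 2 to compound 3 (0.71 log units; beyond the scatter).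

Compound 4 `CCCCNc1nc(N)nc(C)c1CCCn1cccn1` is not yet measured. It differs from compound 3 in one place: 1H-pyrazol-1-yl in place of diethylamino on a saturated chain carbon, three bonds along the chain from an aromatic carbon. Among the compounds with values here, no measured pair swaps one terminal group of this chain for an aromatic ring, so the nearest guide is the exchange of hydroxymethyl for diethylamino, which gave a 5.2-fold lower number from compound 2 to compound 3 (0.71 log units; beyond the scatter), showing that the chain end governs a good part of the spread. Because a 5.2-fold lower number from compound 2 to compound 3 (0.71 log units; beyond the scatter) was obtained by moving away from a group without nitrogen toward diethylamino, the return to a different nitrogen-bearing end is expected to cost some of that gain rather than all of it. Compound 4 is therefore expected to show a 2.6-fold higher number from compound 3 to compound 4 (0.41 log units; beyond the scatter), and its value in this assay is estimated at 650 nM, within a range of 200 nM to 2000 nM.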

Compound 4, half-maximal effective concentration: 1050 nM
Compound 4: middle estimate off by 1.6-fold (0.21 log units), on the low side; the measured number falls inside the stated range.
By their numbers in this assay, from the lowest: compound 3; then compounds 4 and 2 (each within the scatter of the next); then compound 1.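

In this assay, replacing the diethylamino end with 1H-pyrazol-1-yl, a ring with as many heavy atoms, gives a 4.1-fold higher number from compound 3 to compound 4 (0.62 log units; beyond the scatter), so among these compounds a nitrogen at the chain end does not by itself secure the low number of compound 3. The pyrazole end also shows a 1.2-fold lower number from compound 2 to compound 4 (0.10 log units; within the scatter), which lies within the scatter, so this aromatic ring and the hydroxyl-ended chain cannot be told apart here, and of the three chain ends only diethylamino stands apart. Even so, the step of a 3.1-fold lower number from compound 1 to compound 4 (0.49 log units; beyond the scatter) is similar in size to a 2.5-fold lower number from compound 1 to compound 2 (0.40 log units; beyond the scatter), so in these two compounds a chain with a non-amine end still retains a modest gain over the hydrogen of compound 1.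

Nothing shown here explains why the diethylamino end stands apart. Going by these compounds, it also remains open whether dimethylamino, a piperidine or an imidazole at the end of the same chain would reach the number of compound 3, and whether a longer chain would change the gap between the diethylamino and pyrazole ends.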